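Hydrazone aryl variation on a shared triazolyl-pyridyloxy urea core

A few compounds are considered here, and "the series" means these few. Any claim that something is new, unique, unknown or untested is made for them only; others in the source may bear on it.

Measured compounds:
compound 1, `CN(C)CCn1cnnc1-c1cc(Oc2ccc(NC(=O)N/N=C/c3cc(C(C)(C)C)cc(C(C)(C)C)c3O)cc2F)ccn1`, 520 nM
compound 2, `COc1ccc(/C=N/NC(=O)Nc2ccc(Oc3ccnc(-c4nncn4CCN(C)C)c3)c(F)c2)c(OC)c1OC`, 7650 nM

Both numbers come from a functional assay on U-87MG ATCC cells (Homo sapiens) for cytotoxicity, read by MTT assay, with a stated time of 72 h; on this read-out lower numbers stand for stronger inhibition and higher numbers for weaker inhibition. Compound 2 stands at the higher of the two numbers; compound 1 sits a long way lower, and the gap between them lies beyond the scatter of repeated measurements. The two differ in the aryl group attached to the carbon with a double bond to nitrogen, and nothing else.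

Compound 3 is `CN(C)CCn1cnnc1-c1cc(Oc2ccc(NC(=O)N/N=C/c3c(O)ccc4ccccc34)cc2F)ccn1`. Relative to compound 2 it carries 2-hydroxynaphthalen-1-yl in place of 2,3,4-trimethoxyphenyl on a carbon with a double bond to nitrogen. Within the data shown here, no measured pair shows exactly this exchange, so the expectation rests on the two values at hand. Compound 1, whose aryl also carries a hydroxyl group, gives 520 nM, and compound 2, with three methoxy groups and no hydroxyl, gives 7650 nM; on that basis the step from compound 2 to compound 3 is expected to run downward, toward a stronger number, by a 5.1-fold lower number from compound 2 to compound 3 (0.71 log units; beyond the scatter), with wide uncertainty. The estimate for compound 3 in this assay is 1500 nM, expected to fall between 400 nM and 6000 nM.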

Compound 3, half-maximal inhibitory concentration: 620 nM
Compound 3: middle estimate off by 2.4-fold (0.38 log units), on the high side; the measured number falls inside the stated range.
By their numbers in this assay, from the lowest: compounds 1 and 3 (each within the scatter of the next); then compound 2.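

At the carbon with a double bond to nitrogen, replacing 2,3,4-trimethoxyphenyl with 2-hydroxynaphthalen-1-yl gives a large change in this assay (a 12-fold lower number from compound 2 to compound 3 (1.09 log units; beyond the scatter)), the first single-place step read in this series. The position therefore accepts an aryl with two six-membered aromatic rings, and in this assay compound 1 gives (520 nM) and compound 3 gives (620 nM), values within the scatter of each other despite their different aryl groups; among these three compounds, the two whose aryl carries a hydroxyl group share this range, and none goes against that pattern. No measurement available here accounts for the step.

The step removes the three methoxy groups, introduces the hydroxyl and adds a second aromatic ring all at once, so the contribution of each remains unresolved. A 2-methoxynaphthalen-1-yl group would separate the ring from the hydroxyl, and an aryl carrying an amine in place of the hydroxyl would test whether a different group can serve there, so both questions remain open on the compounds shown.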